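The compounds below may be only part of what the source reports. "The series", "measured", "known", "first", "only" and "open" are said of these compounds alone.

Three sulfonamides on a shared core have been run in a functional assay on Bel-7402 cells (Homo sapiens) for antiproliferative activity, read by sulforhodamine B assay, tested at 100 ug/mL (a higher number here means more inhibition at the concentration tested (going by the name of the read-out), a lower number less inhibition), so far. Compound 1 `COc1cc(OC)nc(NS(=O)(=O)C2CCCCC2=O)n1` gives 39.3% in this assay. Compound 2 `O=C1CCCCC1S(=O)(=O)Nc1ccccc1Br` gives 22.1% in this assay. Compound 3 `O=C1CCCCC1S(=O)(=O)Nc1ccc(Cl)cc1C(F)(F)F` gives 21% in this assay. Compound 3 thus holds the lowest of the three numbers: its nearest neighbour is compound 2, whose number lies within the scatter of it, and compound 1 sits furthest away, beyond the scatter.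

Compound 4 `O=C1CCCCC1S(=O)(=O)Nc1ccc(Cl)cc1` has not yet been measured in this assay. It differs from compound 3 in one place: hydrogen in place of trifluoromethyl on an aromatic carbon. Within the data shown here, no measured pair in the set shares this change, so no step size is known for it. Compound 2 at 22.1% and compound 3 at 21% fall within the scatter of each other despite carrying different groups, which gives no sign that a group swap of this kind moves the number far. For compound 4 the expected step in this assay is a number 2 percentage points higher from compound 3 to compound 4 (within the scatter), none beyond the scatter. Compound 4 is estimated at 23%, between 10% and 38%.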

Compound 4, a percentage reported as inhibition, at one concentration (the size of the read-out at that concentration, not a potency): 4.47%
Estimate against measurement, compound 4: 18.5 percentage points above; measured number below the stated range.
By their numbers in this assay, from the lowest: compound 4; then compounds 3 and 2 (each within the scatter of the next); then compound 1.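

In this assay, hydrogen in place of trifluoromethyl on this aromatic carbon, ortho to a large group and meta to a chloro group, gives a number 16.5 percentage points lower from compound 3 to compound 4 (beyond the scatter), the first single-place change read in the series. Among these compounds, compound 4 keeps the shared core and the chloro group, so this step shows that the number depends on what this one place carries, which the earlier compounds, differing in more than one place, could not show. No measurement at hand bears on what lies behind this step.

Going by these compounds, whether the step is specific to trifluoromethyl or would follow any group at this place remains open, and a methyl, a methoxy or a nitrile group here would help separate the two. Also open, on these data alone, is whether the same change keeps its size without the chloro group.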